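Moving a Methyl Around the Phenyl Ring

The source may report more compounds than this note shows. Statements on the series, on what has been measured and on what is new or still open speak of the compounds shown alone.

Of the compounds shown here, two built on the shared core have been measured so far. In a physicochemical assay for solubility, in phosphate buffer, at pH 7.4 (a lower number here means a less soluble compound, a higher number a more soluble compound), compound 1 `CCOC(=O)c1c(-c2ccccc2C)[nH]c2cc(OC)ccc2c1=O` gives > 100000 nM, which is a limit of the measurement rather than a number. Compound 2 `CCOC(=O)c1c(-c2ccc(Cl)cc2)[nH]c2cccc(OC)c2c1=O` also stops at a limit in this assay, giving > 100000 nM. Both measured values therefore rest at the same point, as the limit of > 100000 nM in this assay, at which 2 of the 2 values shown sit, shows, and neither offers a number to compare against.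

Compound 3 `CCOC(=O)c1c(-c2cccc(C)c2)[nH]c2cc(OC)ccc2c1=O` is not yet measured. It differs from compound 1 in one place: 3-methylphenyl in place of 2-methylphenyl on an aromatic carbon. Among the measured compounds shown here, no step between two measured compounds is available to show how large such a change can be. Because every value shown sits at the limit described by the limit of > 100000 nM in this assay, at which 2 of the 2 values shown sit, the step expected in this assay is none beyond the scatter. The estimate for compound 3 in this assay is 100000 nM, with a range from 50000 nM to 200000 nM. The expected step is a number no higher from compound 1 to compound 3 (the limit leaves the size open).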

Compound 3, solubility: 48000 nM
Estimate against measurement, compound 3: 2.1-fold (0.32 log units) above, outside the stated range (below it).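

In this assay, 3-methylphenyl in place of 2-methylphenyl gives an at least 2.0-fold lower number from compound 1 to compound 3 (0.31 log units; beyond the scatter). Among the compounds shown here, compound 3 is the first compound here to give a number rather than a limit, and it shows that this assay can respond when the methyl moves around the phenyl ring, even though the atoms stay the same. Only the minimum size of the step can be read, because compound 1 rests at a limit: the limit of > 100000 nM in this assay, at which 2 of the 3 values shown sit.

The data do not say why moving the methyl lowers the number, or whether the same move would do so elsewhere on the shared core. As far as these compounds go, it also remains open how the number would shift if an amine or a carboxylic acid took the place of the methyl on the phenyl ring.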